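The source may report more compounds than this note shows. Statements on the series, on what has been measured and on what is new or still open speak of the compounds shown alone.

Measured so far:
- compound 1, `O=C(N/N=C/c1ccccc1O)c1ccc(-c2ccc(F)cc2)o1`: 74%
- compound 2, `O=C(N/N=C/c1ccccc1)c1ccc(-c2ccc(Cl)cc2)o1`: 33.7%

In a functional assay on BGC-823 cells (Homo sapiens) for inhibition, read by sulforhodamine B assay, with a stated time of 48 h, tested at 10 uM (a lower number here means less inhibition of growth, a higher number more inhibition of growth at the concentration tested), compound 1 gives 74%, the higher of the two numbers; compound 2 gives 33.7% in this assay, a gap beyond the usual scatter. Going by the values given here, compound 2 differs from compound 1 in more than one place, so its value shows only that a member of the series can sit far lower.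

Compound 3, `O=C(N/N=C/c1ccccc1Cl)c1ccc(-c2ccc(F)cc2)o1`, has yet to be measured. It differs from compound 1 by chloro in place of hydroxy on an aromatic carbon. Among the compounds with values here, no measured pair isolates the loss of the hydroxy, so the size of the step rests on the two values alone. Within the data shown here, the expectation is a step downward, likely beyond the scatter, since the one compound without a hydroxy on that ring sits well below compound 1. The step is estimated as a number 29 percentage points lower from compound 1 to compound 3 (beyond the scatter) in this assay. Compound 3 is expected to give 45%, with a range from 20% to 72%.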

Compound 3, percent growth inhibition at one concentration: 32%
For compound 3 the middle estimate is 13 percentage points above the measured one, within the range that was stated.
By their numbers in this assay, from the lowest: compounds 3 and 2 (each within the scatter of the next); then compound 1.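

Chloro in place of hydroxy on this aromatic carbon, ortho to a large group, gives in this assay a step of a number 42 percentage points lower from compound 1 to compound 3 (beyond the scatter) and is the first change in the series that can be read in one place. Compound 2 could only hint at the importance of this position, whereas this pair shows that the 2-hydroxyphenyl to 2-chlorophenyl change alone is enough for a large loss of growth inhibition on the shared core. The change swaps one heavy atom but also removes the hydrogen-bond donor and acceptor counted for hydroxy, and no measurement at hand tells which part of it matters.

On these data alone, whether a methoxy group or an amine at this carbon would hold the value of compound 1 remains open. Compound 2 differs from compound 3 in more than one place, so the effect of chloro against plain hydrogen here also stays unresolved.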